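The source may report more compounds than this note shows. Statements on the series, on what has been measured and on what is new or still open speak of the compounds shown alone.

Series notes, pyrazolylamino series.

Compound 1 `CCCc1nc(C)c2ccnc(Nc3cc[nH]n3)n12` is one of two members measured in a functional assay for inhibition, with Homo sapiens as the target; on this read-out higher numbers stand for weaker inhibition and lower numbers for stronger inhibition. In this assay compound 1 gives 25000 nM, the lowest of the two numbers. Its nearest neighbour is compound 2 `Cc1nc(C)n2c(Nc3cc[nH]n3)nccc12`, which in this assay gives 53000 nM. Among the measured compounds shown here, the one step so far, a 2.1-fold higher number from compound 1 to compound 2 (0.33 log units; beyond the scatter), replaces ethyl with hydrogen on a saturated chain carbon bound to an aromatic carbon, a change on the chain rather than on the core.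

Compound 3 `CCCc1nc(C)c2c(CC)cnc(Nc3cc[nH]n3)n12` is not yet measured. Compound 3 differs from compound 1 by ethyl in place of hydrogen on an aromatic carbon. For the measured compounds named here, no measured step touches an aromatic carbon of the core, so the step from compound 1 to compound 2 informs only the general scale of change, which was modest. The added group in compound 3 is expected to move the number by no more than a modest step, with direction uncertain; the estimated step is a 1.4-fold lower number from compound 1 to compound 3 (0.14 log units; within the scatter). Compound 3 is therefore expected to give about 18000 nM in this assay, within a range from 5000 nM to 60000 nM.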

Compound 3, half-maximal inhibitory concentration: > 48000 nM
Compound 3: no number, only a limit (the forecaster's own chance of this, stated with the estimate: 15%); middle value at least 2.6-fold (0.42 log units) away from the limit.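

Up to now, no measured step touched an aromatic carbon of the shared core. The carbon para to a (1H-pyrazol-3-yl)amino group now has a first reading, and ethyl in place of hydrogen there gives no sign of stronger inhibition: the step is an at least 1.9-fold higher number from compound 1 to compound 3 (0.28 log units; that floor lies within the scatter). In this assay, on these data alone, compound 3 gives > 48000 nM, which is a limit and not a number, so the true size of the step remains unknown. What can be carried forward from compound 3 therefore comes down to one fact: the limit of > 48000 nM in this assay, at which 1 of the 3 values shown sits.

Whether an amine, a carboxylic acid or a fluorine atom on this same aromatic carbon would give a lower number than hydrogen or ethyl stays open, since ethyl is the only group shown there. Among the compounds shown here, also open is whether a longer chain on the saturated chain carbon bound to an aromatic carbon would extend the trend seen in the only fully numerical step, a 2.1-fold higher number from compound 1 to compound 2 (0.33 log units; beyond the scatter).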